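The source may report more compounds than this note shows. Statements on the series, on what has been measured and on what is new or still open speak of the compounds shown alone.

In an ADME assay on BHK cells (Mesocricetus auratus) for cytotoxicity, read by MTT assay, with a stated time of 96 h (on this read-out lower numbers stand for higher toxicity in this test and higher numbers for lower toxicity in this test), compound 1 (`FC(F)(F)c1cccc(NC(=S)Nc2ccc(Cl)cc2)c1`) reads 10000 nM as measured, compound 2 (`FC(F)(F)c1cccc(NC(=S)Nc2ccccc2)c1`) reads 41000 nM and compound 3 (`Fc1ccc(NC(=S)Nc2cccc(C(F)(F)F)c2)cc1`) reads 26000 nM in the same test. The standing of compound 3 rests on two steps: a 1.6-fold lower number from compound 2 to compound 3 (0.20 log units; within the scatter) and a 2.6-fold higher number from compound 1 to compound 3 (0.41 log units; beyond the scatter) so its number lies within the scatter of one neighbour and clearly on the high side of the other.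

Compound 4 (`C=C(C)CNC(=S)Nc1cccc(C(F)(F)F)c1`) carries 2-methylprop-2-en-1-yl in place of 4-fluorophenyl on an amide-type nitrogen. Going by the values given here, no measured step makes this kind of change. All three only exchange one substituent for another on an aromatic carbon, so they bear on it indirectly. The largest of them is a 4.1-fold higher number from compound 1 to compound 2 (0.61 log units; beyond the scatter) and even that one is modest. Nothing here shows what happens when the aromatic ring on that nitrogen is lost, so only a small rise, not beyond the scatter, is expected in this assay on this thin evidence. The expected step is a 1.5-fold higher number from compound 3 to compound 4 (0.19 log units; within the scatter) and it would stay within the scatter. For compound 4 the estimated value is 40000 nM with an expected range from 15000 nM to 100000 nM in this test.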

Compound 4, half-maximal cytotoxic concentration: > 100000 nM
Compound 4: no number, only a limit (the forecaster's own chance of this, stated with the estimate: 20%); middle value at least 2.5-fold (0.39 log units) from the limit.
By their numbers in this assay, from the lowest: compound 1; then compounds 3 and 2 (each within the scatter of the next). At a limit, above all of these: compound 4.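

In this assay the reading of compound 4 is a limit of the assay and not a number: the limit of > 100000 nM in this assay, at which 1 of the 4 values shown sits. The earlier compounds shown here varied only a substituent on an aromatic carbon, whereas here the whole aromatic group on the amide-type nitrogen is exchanged, and 2-methylprop-2-en-1-yl in place of 4-fluorophenyl gives an at least 3.8-fold higher number from compound 3 to compound 4 (0.58 log units; beyond the scatter), while the same group in place of phenyl gives an at least 2.4-fold higher number from compound 2 to compound 4 (0.38 log units; beyond the scatter). In place of 4-chlorophenyl it gives an at least 10-fold higher number from compound 1 to compound 4 (1.00 log units; beyond the scatter), so all three steps lie beyond the scatter and show that this position can shift the read-out towards lower toxicity in this test, with compound 4 standing clear of all three aryl compounds.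

From the compounds shown here alone, since compound 4 sits at a limit, the true size of these steps stays open, and only their lower bounds can be read. The compounds shown also cannot separate the loss of the aromatic ring from the arrival of the double bond: a saturated chain such as 2-methylpropyl, or a cyclohexyl or benzyl group on the same nitrogen, would be needed to tell these apart.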